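The source may report more compounds than this note shows. Statements on the series, on what has been measured and on what is new or still open speak of the compounds shown alone.

Three compounds of a shared core have been run in a functional assay on SK-BR-3 cells (Homo sapiens) for inhibition, read by MTT assay, with a stated time of 2 days, tested at 10 uM; on this read-out lower numbers stand for less inhibition of growth and higher numbers for more inhibition of growth at the one concentration tested. Compound 1 `CNC(=O)c1cc(Oc2ccc3nc(NC(=O)Nc4cc(C(F)(F)F)cc(C(F)(F)F)c4)sc3c2)ccn1` gives 88.1%, compound 2 `CNC(=O)c1cc(Oc2ccc3nc(NC(=O)c4ccc(Cl)cc4)sc3c2)ccn1` gives 18.9%, and compound 3 `CNC(=O)c1cc(Oc2ccc3nc(NC(=O)c4cc(C(F)(F)F)cc(C(F)(F)F)c4)sc3c2)ccn1` gives 8.56%. Among these three numbers compound 2 stands second highest; its nearest neighbour is compound 3, lower by a gap beyond the scatter, while compound 1 lies far above it, again beyond the scatter. For the measured compounds named here, nothing more can be said of the pairs than what their values show, since no single-point step between them is recorded.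

The next compound, compound 4 `CNC(=O)c1cc(Oc2ccc3nc(NC(=O)Nc4ccc(F)cc4)sc3c2)ccn1`, has not yet been measured. It differs from compound 2 in one place: (4-fluorophenyl)amino in place of 4-chlorophenyl on a carbonyl carbon. Written one bond further out, the change reads (4-chlorophenyl)carbonyl to (4-fluorophenyl)carbamoyl.

The expectation rests on what is seen. Compound 1, which gives 88.1%, carries the carbamoyl-type link that compound 4 also carries, whereas the two compounds with a carbonyl link sit lower: compound 2 gives 18.9%, and compound 3 gives 8.56%. Compound 4 is therefore expected to move upward from compound 2 by a step beyond the scatter, a number 36.1 percentage points higher from compound 2 to compound 4 (beyond the scatter), though the ring substituent differs from compound 1, so the size is uncertain. Compound 4 is estimated at 55%, within 25% to 85%.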

Compound 4, percent growth inhibition at one concentration: 14.2%
For compound 4 the middle estimate is 40.8 percentage points above the measured one; the whole stated range lies above it.
By their numbers in this assay, from the lowest: compounds 3, 4 and 2 (each within the scatter of the next, the first and the last beyond it); then compound 1.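

In this assay, putting (4-fluorophenyl)amino in place of 4-chlorophenyl on a carbonyl carbon gives a number 4.7 percentage points lower from compound 2 to compound 4 (within the scatter), so this single exchange separates compound 2 and compound 4 by no more than the usual scatter. The result also shows that the carbamoyl link alone does not account for the value of compound 1: compound 1, with its two trifluoromethyl groups, gives 88.1%, while compound 4, with the same link and a 4-fluorophenyl ring, gives 14.2%. Nothing in the available data explains this outcome, and no measurement beyond the growth inhibition figures bears on it.

The step from compound 2 to compound 4 exchanges the link and the halogen together, so the compounds shown leave open what each contributes alone, which (4-chlorophenyl)amino or 4-fluorophenyl on the same carbonyl carbon could help to separate. They also leave open whether the carbamoyl link tolerates other groups on its far side, such as a single trifluoromethyl on the phenyl ring, a nitrile, or a cyclohexyl ring in place of the phenyl ring.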